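A Hydroxyl on the Ethyl Chain of Compound 1

This account rests on a few compounds, and the source may have more. Where it says the series, first, only, none or still open, it means among the compounds named here.

Compound 1 `CCc1c(F)c(N)c2c(=O)cc(-c3ccc(N)c(F)c3)oc2c1F` gives 130 nM in a functional assay on MCF7 cells (Homo sapiens) for cytotoxicity, read by neutral red uptake, with a stated time of 3 days (a higher number here means a weaker inhibitor, a lower number a stronger inhibitor), the lower of the two numbers shown. Its nearest neighbour is compound 2 `C[S+]([O-])c1c(F)c(N)c2c(=O)cc(-c3ccc(N)c(F)c3)oc2c1F`, which gives 2500 nM, a 19-fold higher number from compound 1 to compound 2 (1.28 log units; beyond the scatter). Compound 3 `Nc1ccc(-c2cc(=O)c3c(N)c(F)c(O)c(F)c3o2)cc1F` reaches only a limit of the assay, > 10000 nM, so (the limit of > 10000 nM in this assay, at which 1 of the 3 values shown sits). The step of an at least 76-fold higher number from compound 1 to compound 3 (1.88 log units; beyond the scatter) is thus known only as a bound. Compound 4 `Nc1ccc(-c2cc(=O)c3c(N)c(F)c(CO)c(F)c3o2)cc1F` differs from compound 1 by hydroxy in place of methyl on a saturated chain carbon bound to an aromatic carbon. Both measured steps away from compound 1 replace its ethyl and push the number sharply upward, so a rise beyond the scatter is expected here as well, though the chain itself is kept and only its end is changed, which argues for a smaller rise. Compound 4 is therefore expected to give 1500 nM, between 400 nM and 6000 nM, which is a 12-fold higher number from compound 1 to compound 4 (1.06 log units; beyond the scatter).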

Compound 4, half-maximal inhibitory concentration: 62 nM
Beside the measured number, compound 4's estimate is 24-fold (1.38 log units) above it; the measured number lies below the stated range.
By their numbers in this assay, from the lowest: compound 4; then compound 1; then compound 2. At a limit, above all of these: compound 3.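

Every earlier change at this position raised the number, but ending the chain in hydroxy instead gives a 2.1-fold lower number from compound 1 to compound 4 (0.32 log units; beyond the scatter) and so shows that this position can carry a hydroxy group on a saturated chain carbon. The hydroxymethyl of compound 4 also compares well with the group on compound 2, with a 40-fold lower number from compound 2 to compound 4 (1.61 log units; beyond the scatter) on the same core. Hydroxymethyl in place of hydroxy gives an at least 160-fold lower number from compound 3 to compound 4 (2.20 log units; beyond the scatter), a step known only as a bound: the limit of > 10000 nM in this assay, at which 1 of the 4 values shown sits.

Still open, going by these compounds, is whether a longer chain ending in hydroxy, or an amine or a carboxylic acid on that same carbon, would keep the number this low. These compounds also do not show what lies behind the drop.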